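Lengthening the hydroxy chain of compound 2

This account rests on a few compounds, and the source may have more. Where it says the series, first, only, none or still open, it means among the compounds named here.

In a physicochemical assay for solubility, at pH 7.4 (on this read-out higher numbers stand for higher solubility and lower numbers for lower solubility), compound 1 `NS(=O)(=O)c1ccc(S(=O)(=O)CC(O)CO)cc1` gives 14900 ug/mL against compound 2 `NS(=O)(=O)c1ccc(SCCO)c(F)c1` at 6000 ug/mL as the lower of the two numbers, a gap beyond the scatter. Compound 3 `NS(=O)(=O)c1ccc(SCCCCO)c(F)c1` is still unmeasured and differs from compound 2 by 2-hydroxyethyl in place of hydroxy on a saturated chain carbon, two bonds along the chain from a sulfur in one place: 2-hydroxyethyl in place of hydroxy on a saturated chain carbon, two bonds along the chain from a sulfur. Among the compounds with values here, no measured pair shows this change, so the forecast is a judgement. The step expected in this assay is a moderate fall beyond the scatter, estimated as a 3.0-fold lower number from compound 2 to compound 3 (0.48 log units; beyond the scatter) in size. Compound 3 is estimated at 2000 ug/mL within an expected range of 700 ug/mL to 5000 ug/mL for this measurement.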

Compound 3, solubility: 1000 ug/mL
The estimate for compound 3 lay 2.0-fold (0.30 log units) above the measured number; measured number inside the range.
By their numbers in this assay, from the lowest: compound 3; then compound 2; then compound 1.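

Within the data shown here, this is the first measured pair that differs in one place. In this assay, 2-hydroxyethyl in place of hydroxy on a saturated chain carbon, two bonds along the chain from a sulfur, gives a 6.0-fold lower number from compound 2 to compound 3 (0.78 log units; beyond the scatter). The position therefore responds to this change, even though the entering group, like the one leaving, ends in a hydroxy group.

As far as these compounds go, whether a longer chain, or an amine at the chain end, would give a number lower still stays open with only these compounds. Nothing shown explains the step.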